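The compounds below may be only part of what the source reports. "The series", "measured", "known", "first", "only" and "open" are said of these compounds alone.

In an ADME assay on MDCK cells (Canis lupus familiaris) for cytotoxicity, read by MTT assay, with a stated time of 2 days (on this read-out lower numbers stand for higher toxicity in this test and higher numbers for lower toxicity in this test), compound 3 (`BrCCCCc1ccc(-c2ccc(-c3ccc(-c4cccs4)s3)s2)s1`) has the entry "not determined" (no result reported) and therefore no number of its own. The values around it are few. Compound 1 (`BrCCCCc1ccc(-c2ccc(-c3ccc(CCCCBr)s3)s2)s1`) gives > 200000 nM in this assay and this is a limit, not a number. That reading of compound 1 is the limit of > 200000 nM in this assay, at which 1 of the 3 values shown sits, in this small set. Going by the values given here, the only true number belongs to compound 2 (`NCCCCc1ccc(-c2ccc(-c3cccs3)s2)s1`) at 13300 nM in this assay.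

The next compound, compound 4 (`BrCCCCc1ccc(-c2ccc(-c3cccs3)s2)s1`), has not yet been measured. The structural change is hydrogen in place of thiophen-2-yl on an aromatic carbon with hydrogen in place of thiophen-2-yl on an aromatic carbon, on a five-membered aromatic ring with 1 sulfur.

With no number for compound 3, this step has no starting value, so no size can be set on it. Compound 4 keeps the bromobutyl chain of compound 1 and lacks the amine of compound 2. On that basis, and with compound 2 at 13300 nM in this assay, compound 4 is expected to read higher than compound 2 by a margin beyond the usual scatter, which would mean lower toxicity in this test. In this assay the estimated value for compound 4 is 60000 nM with an expected range of 20000 nM to 200000 nM for this compound.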

Compound 4, half-maximal cytotoxic concentration: 23800 nM
Beside the measured number, compound 4's estimate is 2.5-fold (0.40 log units) above it; measured number inside the range.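

In this assay, bromo in place of amino on a saturated chain carbon, four bonds along the chain from an aromatic carbon, gives a 1.8-fold higher number from compound 2 to compound 4 (0.25 log units; within the scatter), so this read-out does not separate the two chain ends on this core. Hydrogen in place of 4-bromobutyl on an aromatic carbon gives an at least 8.4-fold lower number from compound 1 to compound 4 (0.92 log units; beyond the scatter); for this one pair, the compound without the second bromobutyl chain is the one with the higher toxicity in this test, and the printed size of the step is only a minimum. Compound 1 remains a limit of the assay, not a number: the limit of > 200000 nM in this assay, at which 1 of the 4 values shown sits.

As far as these compounds go, the step from compound 3 to compound 4 cannot be read, so the effect of thiophen-2-yl on an aromatic carbon of a five-membered aromatic ring with 1 sulfur remains open. Also open, from the compounds shown here alone, is whether a carboxylic acid or a hydroxyl at the chain end, or a longer chain in place of the butyl chain, would read apart from compound 2 and compound 4.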